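Triazole nitrogen substituent: oxetan-3-yl replacing isopropyl

A few compounds are considered here, and "the series" means these few. Any claim that something is new, unique, unknown or untested is made for them only; others in the source may bear on it.

For the measured compounds named here, compound 2 `CC(C)n1nc(C(=O)N[C@H]2COc3ccccc3N(C)C2=S)nc1Cc1ccccc1` gives 360 nM in a functional assay on HT-29 cells (Homo sapiens) for inhibition, read by luminescence and CellTiter-Glo, with a stated time of 24 h (on this read-out lower numbers stand for an effect already at smaller amounts and higher numbers for an effect only at larger amounts of compound), the lowest of the three numbers so far. Compound 1 `CCCCCn1nc(C(=O)N[C@H]2COc3ccccc3N(C)C2=S)nc1Cc1ccccc1` gives 805 nM and compound 3 `CC(C)Cn1nc(C(=O)N[C@H]2COc3ccccc3N(C)C2=S)nc1Cc1ccccc1` gives 1230 nM; the steps to compound 2 are a 2.2-fold lower number from compound 1 to compound 2 (0.35 log units; beyond the scatter) and, in the other direction, a 3.4-fold higher number from compound 2 to compound 3 (0.53 log units; beyond the scatter). Compound 4 `CN1C(=S)[C@@H](NC(=O)c2nc(Cc3ccccc3)n(C3COC3)n2)COc2ccccc21` carries the change (oxetan-3-yl in place of isopropyl on an aromatic nitrogen).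

Both measured steps that alter the group on the aromatic nitrogen of compound 2 move the number beyond the scatter, and in each case away from compound 2, so this position is sensitive to what sits there. No measured compound carries a ring or an acceptor at this position, so the direction for oxetan-3-yl is not anchored by any step shown. Given that both changes from isopropyl so far were unfavourable, the expectation for compound 4 is a modest step of a 1.8-fold higher number from compound 2 to compound 4 (0.26 log units; within the scatter) in this assay, with wide uncertainty. Compound 4 is estimated at 650 nM, range 200 nM to 2200 nM.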

Compound 4, half-maximal effective concentration: 916 nM
Compound 4: the middle estimate sits 1.4-fold (0.15 log units) below what was measured, within the range that was stated.
By their numbers in this assay, from the lowest: compound 2; then compounds 1, 4 and 3 (each within the scatter of the next).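

In this assay, oxetan-3-yl brings the first ring and the first hydrogen-bond acceptor to this aromatic nitrogen, and the change gives a 2.5-fold higher number from compound 2 to compound 4 (0.41 log units; beyond the scatter), so all three replacements of isopropyl shown here give a higher number. Set against the open-chain groups, oxetan-3-yl gives a 1.3-fold lower number from compound 3 to compound 4 (0.13 log units; within the scatter) and a 1.1-fold higher number from compound 1 to compound 4 (0.06 log units; within the scatter), both within the scatter, so this assay does not separate it from isobutyl or pentyl. Nothing available bears on why the step takes this direction.

The compounds shown leave open whether the step from isopropyl follows from the four-membered ring or from its oxygen, a question a cyclobutyl group on this nitrogen would address. Also open, as far as these compounds go, is how a methyl or ethyl group, or an azetidin-3-yl amine, would compare with isopropyl.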